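Replacing Hydrogen on Sulfur with Methoxymethyl

The source may report more compounds than this note shows. Statements on the series, on what has been measured and on what is new or still open speak of the compounds shown alone.

- Compound 1 `CC(C)c1n[nH]c2c(NCc3ccc(-c4ccccn4)cc3)nc(SCC(N)CN)nc12`: 480 nM
- Compound 2 `CC(C)c1n[nH]c2c(NCc3ccc(-c4ccccn4)cc3)nc(SCCNC(N)=O)nc12`: 240 nM
- Compound 3 `CC(C)c1n[nH]c2c(NCc3ccc(-c4ccccn4)cc3)nc(S)nc12`: 2760 nM

In a functional assay on HT cells (Homo sapiens) for antiproliferative activity, read by fluorescence, with a stated time of 72 h (a higher number here means a weaker inhibitor of growth, a lower number a stronger inhibitor of growth), compound 3 gives 2760 nM, the highest number of the three and so the weakest growth inhibition. Compound 4 `COCSc1nc(NCc2ccc(-c3ccccn3)cc2)c2[nH]nc(C(C)C)c2n1` differs from it by methoxymethyl in place of hydrogen on a sulfur, with methoxymethyl in place of hydrogen on a sulfur. Among the compounds with values here, two measured steps bear on this change, both also differing at that sulfur: a 5.8-fold higher number from compound 1 to compound 3 (0.76 log units; beyond the scatter) and a 12-fold higher number from compound 2 to compound 3 (1.06 log units; beyond the scatter). Read in reverse, each shows a substituted sulfur giving the lower number, although neither chain is methoxymethyl. A modest to large drop is therefore expected, and the estimated step is a 4.6-fold lower number from compound 3 to compound 4 (0.66 log units; beyond the scatter). The estimate for compound 4 is 600 nM, with an expected range of 200 nM to 1800 nM.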

Compound 4, concentration for 50% growth inhibition: 340 nM
Compound 4: middle estimate off by 1.8-fold (0.25 log units), on the high side; the measured number falls inside the stated range.
By their numbers in this assay, from the lowest: compounds 2, 4 and 1 (each within the scatter of the next); then compound 3.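

In this assay, methoxymethyl on the sulfur also gives a lower number, an 8.1-fold lower number from compound 3 to compound 4 (0.91 log units; beyond the scatter), so this gain does not need the nitrogen-bearing chains of compound 1 and compound 2. The chain's identity makes no readable difference among these three compounds: a 1.4-fold higher number from compound 2 to compound 4 (0.15 log units; within the scatter) and a 1.4-fold lower number from compound 1 to compound 4 (0.15 log units; within the scatter) both lie within the scatter. The compounds shown leave open whether a carboxylic acid or a longer alkyl chain on the sulfur would keep this level. No measurement here explains why substituting the sulfur lowers the number.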